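A few compounds are considered here, and "the series" means these few. Any claim that something is new, unique, unknown or untested is made for them only; others in the source may bear on it.

Compound 1, `CC(=O)OC[C@H]1O[C@@H](CC(=O)/C=C/c2cccc(NC(=O)Nc3ccccc3)c2)[C@H](OC(C)=O)[C@@H](OC(C)=O)[C@@H]1OC(C)=O`, gives 180000 nM in an ADME assay on Vero cells (Chlorocebus sabaeus) for cytotoxicity, read by resazurin assay, with a stated time of 2 days; a lower number here means that less compound is tolerated, a higher number that more compound is tolerated.
Compound 2, `COc1ccc(NC(=O)Nc2cccc(/C=C/C(=O)C[C@@H]3O[C@H](CO)[C@@H](O)[C@H](O)[C@H]3O)c2)c([N+](=O)[O-])c1`, gives 709000 nM in this assay.
Compound 3, `COc1ccc(NC(=O)Nc2cccc(/C=C/C(=O)C[C@@H]3O[C@H](COC(C)=O)[C@@H](OC(C)=O)[C@H](OC(C)=O)[C@H]3OC(C)=O)c2)c([N+](=O)[O-])c1`, gives 730000 nM in this assay.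

Compound 2 and compound 3 rest on two different cores; how the two cores differ is not broken down here, and their two values lie within the scatter of each other. Between compound 3 and compound 1 the only change is phenyl in place of 4-methoxy-2-nitrophenyl on an amide-type nitrogen, and it produced a 4.1-fold lower number from compound 3 to compound 1 (0.61 log units; beyond the scatter). Compound 4, `O=C(/C=C/c1cccc(NC(=O)Nc2ccccc2)c1)C[C@@H]1O[C@H](CO)[C@@H](O)[C@H](O)[C@H]1O`, is made from compound 2 by phenyl in place of 4-methoxy-2-nitrophenyl on an amide-type nitrogen, the same change at the same kind of place. The step from compound 2 to compound 4 is therefore expected to be of about the same size, a 4.1-fold lower number from compound 2 to compound 4 (0.61 log units; beyond the scatter), resting on the step of a 4.1-fold lower number from compound 3 to compound 1 (0.61 log units; beyond the scatter) seen on the other core. Compound 4 is thus estimated at 175000 nM in this assay, expected to fall between 70000 nM and 450000 nM.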

Compound 4, half-maximal cytotoxic concentration: 373000 nM
For compound 4 the middle estimate is 2.1-fold (0.33 log units) below the measured one; the range from low to high includes it.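

In this assay, putting phenyl in place of 4-methoxy-2-nitrophenyl on the amide-type nitrogen gives a 1.9-fold lower number from compound 2 to compound 4 (0.28 log units; within the scatter), so on this core the change cannot be told apart from repeat-measurement noise. Set beside the earlier step, the two cores show no real disagreement: the same change on two cores in this assay, a 4.1-fold lower number (0.61 log units; beyond the scatter) from compound 3 to compound 1 and a 1.9-fold lower number (0.28 log units; within the scatter) from compound 2 to compound 4, 2.1-fold (0.33 log units) apart, within the scatter of two such steps. This supports carrying the change between these two cores as a rough guide, but with one pair per core it does not show that the step has a fixed size or that it would hold on any other core.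

From the compounds shown here alone, what remains open is which part of 4-methoxy-2-nitrophenyl matters, a question that 4-methoxyphenyl or 2-nitrophenyl on the same nitrogen would address. Going by these compounds, whether a third core would follow also remains open.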